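The source may hold more compounds than are shown below. What is called first, only, known or untested is meant among the compounds shown, and "the series" means these compounds.

The measured compounds are:
compound 1, `CCCCNc1nc(N)nc(C)c1CCCCc1ccccc1`, giving 857 nM in an assay on HEK293 cells for agonist activity at Toll-like receptor 8 (Homo sapiens), read by spectrophotometry; on this read-out lower numbers stand for an effect already at smaller amounts and higher numbers for an effect only at larger amounts of compound
compound 2, `CCCCNc1nc(N)nc(C)c1CCCCO`, giving 1310 nM in this assay

Compound 2 stands within the scatter of compound 1, the only other number shown: the step of a 1.5-fold higher number from compound 1 to compound 2 (0.18 log units; within the scatter) does not rise above the usual variation of the assay. The unmeasured compound 3, `CCCCNc1nc(N)nc(C)c1C`, shares the same core and differs from compound 2 in one place: hydrogen in place of 3-hydroxypropyl on a saturated chain carbon bound to an aromatic carbon. For the measured compounds named here, only one measured step bears on this change, and only loosely: a 1.5-fold higher number from compound 1 to compound 2 (0.18 log units; within the scatter) exchanged the group at the far end of the chain while the chain itself stayed. The present change removes the chain and leaves a hydrogen. Going by the values given here, no measured pair covers this. Since the outer end of the chain was swapped without a step beyond the scatter, the data give no sign of how much the chain itself carries, so the expectation is uncertain and leans toward a weaker effect. The step expected for compound 3 is a 2.3-fold higher number from compound 2 to compound 3 (0.36 log units; beyond the scatter). Compound 3 is estimated at 3000 nM in this assay, within a range from 1000 nM to 12000 nM.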

Compound 3, half-maximal effective concentration: 3280 nM
For compound 3 the middle estimate is 1.1-fold (0.04 log units) below the measured one; measured number inside the range.
By their numbers in this assay, from the lowest: compounds 1 and 2 (each within the scatter of the next); then compound 3.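

In this assay, for the compounds shown here, the exchange of 3-hydroxypropyl for hydrogen, on a saturated chain carbon bound to an aromatic carbon, gives a 2.5-fold higher number from compound 2 to compound 3 (0.40 log units; beyond the scatter) and so yields the first step that lies beyond the scatter, though only a modest one. Going by these compounds alone, exchanging the far end of the chain had given only a 1.5-fold higher number from compound 1 to compound 2 (0.18 log units; within the scatter) while the chain stayed in place, so the earlier compounds could not show whether the chain counted for anything at this position. Now the data show that cutting the chain back moves the number upward, while phenyl and hydroxy at its end remain indistinguishable; no measurement shown here offers an explanation for this step.

The compounds shown leave open whether the step grows gradually with chain length or appears only once the chain is gone, a question that an ethyl or a propyl group at this position would address. They also leave open whether an amine or a carboxylic acid at the end of the chain would stay within the scatter of compound 2 or move the number in either direction.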